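Moving a methyl group around the ring of an imine

The compounds below may be only part of what the source reports. "The series", "measured", "known", "first", "only" and "open" are said of these compounds alone.

Of the compounds shown here, three sharing one core have been tested in a functional assay on cells (Homo sapiens) for cytotoxicity, read by MTT assay, with a stated time of 24 h; a higher number here means a weaker inhibitor, a lower number a stronger inhibitor. Compound 1 `CCCCCCCCCCCCCCNC(=O)[C@H](CO)/N=C/c1cccc(C)c1` gives 82900 nM, the highest of the three numbers and so the weakest inhibitor. Compound 2 `CCCCCCCCCCCCCCNC(=O)[C@H](CO)/N=C/c1ccccc1O` gives 19000 nM, and compound 3 `CCCCCCCCCCCCCCNC(=O)[C@H](CO)/N=C/c1ccccc1` gives 7670 nM, the lowest of the three.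

Compound 4 `CCCCCCCCCCCCCCNC(=O)[C@H](CO)/N=C/c1ccccc1C` differs from compound 1 in one place: 2-methylphenyl in place of 3-methylphenyl on a carbon with a double bond to nitrogen. The measured steps that bear on this change all move away from compound 1. Removing the methyl group entirely gave an 11-fold lower number from compound 1 to compound 3 (1.03 log units; beyond the scatter), and replacing the 3-methylphenyl with a 2-hydroxyphenyl gave a 4.4-fold lower number from compound 1 to compound 2 (0.64 log units; beyond the scatter); in turn, a 2.5-fold lower number from compound 2 to compound 3 (0.39 log units; beyond the scatter) shows that a ring bearing a group on that carbon sat between the other two. A 2-methylphenyl is therefore expected to land between compound 1 and compound 3, giving a modest step downward, a 3.3-fold lower number from compound 1 to compound 4 (0.52 log units; beyond the scatter). For compound 4 the estimate in this assay is 25000 nM, with a range from 8000 nM to 80000 nM.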

Compound 4, half-maximal inhibitory concentration: 87700 nM
Compound 4: middle estimate off by 3.5-fold (0.55 log units), on the low side, and the stated range ends below it.
By their numbers in this assay, from the lowest: compound 3; then compound 2; then compounds 1 and 4 (each within the scatter of the next).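

Changing 3-methylphenyl to 2-methylphenyl on the carbon with a double bond to nitrogen produces no difference that can be told apart in this assay (a 1.1-fold higher number from compound 1 to compound 4 (0.02 log units; within the scatter)), so these two methyl placements cannot be separated by this read-out. The presence of the methyl matters far more than its placement: adding it to the unsubstituted ring gives a large step (an 11-fold higher number from compound 3 to compound 4 (1.06 log units; beyond the scatter)), and putting it in place of the hydroxy group gives a modest one (a 4.6-fold higher number from compound 2 to compound 4 (0.66 log units; beyond the scatter)). No measurement is available to explain why the methyl compounds give higher numbers.

The compounds shown leave open whether a methoxy group, a chlorine or an amine in place of the methyl would also give a higher number than compound 3. They also leave open whether a second methyl on the ring would change the number further.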